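From Methyl to a Dimethoxyphenyl Ethenyl Group

This account rests on a few compounds, and the source may have more. Where it says the series, first, only, none or still open, it means among the compounds named here.

Measured compounds:
Compound 1 `COc1ccc(/C=C/C(=O)c2ccccc2OCC(=O)NCCNc2ccnc3cc(Cl)ccc23)cc1` gives 25000 nM.
Compound 2 `CC(=O)c1ccccc1OCC(=O)NCCNc1ccnc2cc(Cl)ccc12` gives 106000 nM.

Of the compounds shown here, two have been measured in an ADME assay on Vero cells (Chlorocebus sabaeus) for cytotoxicity, read by MTT assay, with a stated time of 72 h; on this read-out lower numbers stand for higher toxicity in this test and higher numbers for lower toxicity in this test. Compound 2 stands at the highest of the two numbers; its nearest neighbour is compound 1, and the step of a 4.2-fold higher number from compound 1 to compound 2 (0.63 log units; beyond the scatter) lies beyond the scatter. Compound 3 `COc1ccc(/C=C/C(=O)c2ccccc2OCC(=O)NCCNc2ccnc3cc(Cl)ccc23)cc1OC` differs from compound 2 by 2-(3,4-dimethoxyphenyl)ethenyl in place of methyl on a carbonyl carbon. Among the compounds with values here, only one measured step bears on this change, the one from compound 1 to compound 2, in which a methyl replaced a methoxyphenyl ethenyl group on the same carbonyl carbon and raised the number by a modest margin. Compound 3 reverses that exchange and carries one more methoxy group on the aromatic ring. The expected step of a 4.8-fold lower number from compound 2 to compound 3 (0.68 log units; beyond the scatter) is therefore a lowering of roughly the size seen before, in the opposite direction. Compound 3 is estimated at 22000 nM, with a range from 8000 nM to 60000 nM.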

Compound 3, half-maximal cytotoxic concentration: 5310 nM
Compound 3: middle estimate off by 4.1-fold (0.62 log units), on the high side; the whole stated range lies above it.
By their numbers in this assay, from the lowest: compound 3; then compound 1; then compound 2.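

In this assay the exchange of methyl for 2-(3,4-dimethoxyphenyl)ethenyl on a carbonyl carbon gives a 20-fold lower number from compound 2 to compound 3 (1.30 log units; beyond the scatter) and so counts as a large step, larger than the earlier exchange between compound 1 and compound 2. The second methoxy group matters on its own: methoxy in place of hydrogen on an aromatic carbon gives a 4.7-fold lower number from compound 1 to compound 3 (0.67 log units; beyond the scatter) and lies beyond the scatter, so in these compounds the number depends on the substitution of the aromatic ring as well as on the presence of the ethenyl group. No measurement given here explains either step.

Going by these compounds, it remains open whether an amine or a carboxylic acid in place of the added methoxy would lower the number as well. On these data alone, it also remains open whether a saturated chain in place of the ethenyl link would keep this lower number.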